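A few compounds are considered here, and "the series" means these few. Any claim that something is new, unique, unknown or untested is made for them only; others in the source may bear on it.

In a functional assay on DU-145 cells (Homo sapiens) for inhibition, read by trypan blue exclusion, with a stated time of 96 h (a higher number here means a weaker inhibitor of growth, a lower number a stronger inhibitor of growth), compound 1 (`Cc1ccc(S/C(=C/c2ccc(Br)cc2)C(=O)c2ccc(Cl)cc2)cc1`) gives 25000 nM as the highest and so the weakest of three measured numbers. Compound 2 (`COc1ccc(/C=C(/SCc2ccc(Cl)cc2)C(=O)c2ccc(Br)cc2)cc1O`) stands at 1000 nM and compound 3 (`O=C(/C(=C\c1ccc(Br)cc1)SCc1ccc(Cl)cc1)c1ccc(Cl)cc1`) stands at 1000 nM on this scale. Compound 4 (`Cc1ccc(S/C(=C/c2ccc[nH]2)C(=O)c2ccc(Cl)cc2)cc1`) has not been measured and differs from compound 1 in one place (1H-pyrrol-2-yl in place of 4-bromophenyl on a double-bonded chain carbon bound to a double-bonded chain carbon). Among the measured compounds shown here, the only measured step (a 25-fold lower number from compound 1 to compound 3 (1.40 log units; beyond the scatter)) is large but concerns the group on sulfur. For the measured compounds named here, no measured step covers a change on the double-bonded chain carbon, so in this assay only a small shift toward a lower number is expected, with none clearly beyond the scatter. The expected step is small (a 1.7-fold lower number from compound 1 to compound 4 (0.22 log units; within the scatter)). Compound 4 is estimated at 15000 nM with an expected range of 4000 nM to 40000 nM for now.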

Compound 4, concentration for 50% growth inhibition: 10000 nM
Compound 4: middle estimate off by 1.5-fold (0.18 log units), on the high side, within the range that was stated.
By their numbers in this assay, from the lowest: compounds 2 and 3 (each within the scatter of the next); then compound 4; then compound 1.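

In this assay, placing 1H-pyrrol-2-yl in place of 4-bromophenyl gives a 2.5-fold lower number from compound 1 to compound 4 (0.40 log units; beyond the scatter), a modest step. This shows that the double-bonded chain carbon is also a place where a change can shift the number, not only the group on sulfur. The entering five-membered ring has fewer heavy atoms and one hydrogen-bond donor, but nothing available accounts for the step.

Still open, as far as these compounds go, is how a furan-2-yl or 1-methylpyrrol-2-yl group would behave at this position. Also open, from the compounds shown here alone, is whether 1H-pyrrol-2-yl and 4-chlorobenzyl on sulfur would work together.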